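The compounds below may be only part of what the source reports. "The series", "measured", "known", "first", "only" and "open" are said of these compounds alone.

Measured so far in an assay for inhibition of Alpha amylase (Homo sapiens), with a stated time of 30 min; on this read-out lower numbers stand for stronger inhibition and higher numbers for weaker inhibition:
- compound 1 `CCOC(=O)c1c(-c2ccccc2)nn(-c2ccccc2)c1Cn1c(S)nc2ccc(OC(F)F)cc21`: 10 ug/mL
- compound 2 `CCOC(=O)c1c(-c2ccccc2)nn(-c2ccccc2)c1COc1cc(OC)c(C=O)c(OC)c1`: 40 ug/mL
- compound 3 `CCOC(=O)c1c(-c2ccccc2)nn(-c2ccccc2)c1Cn1cnc2cc([N+](=O)[O-])ccc21`: 30 ug/mL

Compound 2 gives the highest number of the three. Compound 3 sits nearest to it, and the gap between compound 2 and compound 3 lies within the scatter, so no order can be read between these two. Compound 1 lies furthest from compound 2, with a lower number, and that gap lies beyond the scatter.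

Compound 4 `CCOC(=O)c1c(-c2ccccc2)nn(-c2ccccc2)c1COCc1ccccc1` has not been measured in this assay. It differs from compound 2 in one place: a group of 7 heavy atoms (7 carbon; one six-membered aromatic ring of carbon only) in place of a group of 12 heavy atoms (9 carbon, 3 oxygen; one six-membered aromatic ring of carbon only), on an oxygen on a saturated carbon

Among the measured compounds shown here, no step between two measured compounds shares this kind of change, so there is nothing to anchor the expected size on. The three measured numbers span a modest range, and the change keeps the shared core and the ethyl ester untouched. The working expectation is therefore a step of no more than the scatter in either direction, with the number for compound 4 estimated at 50 ug/mL (range 20 ug/mL to 150 ug/mL), which would mean an expected step of a 1.3-fold higher number from compound 2 to compound 4 (0.10 log units; within the scatter).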

Compound 4, half-maximal inhibitory concentration: 45 ug/mL
For compound 4 the middle estimate is 1.1-fold (0.05 log units) above the measured one; low and high end bracket the measured number.
By their numbers in this assay, from the lowest: compound 1; then compounds 3, 2 and 4 (each within the scatter of the next).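

In this assay, among the compounds shown here, the one step at this position gives a 1.1-fold higher number from compound 2 to compound 4 (0.05 log units; within the scatter), with benzyl in place of the group of 12 heavy atoms on an oxygen on a saturated carbon. Benzyl has 0 hydrogen-bond acceptors and no double bond outside aromatic rings, whereas the group it replaces has 3 hydrogen-bond acceptors and 1 such double bond, so in this pair these features show no readable contribution to the number. No available evidence bears on why the two compounds read alike.

Still open, on these data alone, is whether an amine or a carboxylic acid on the benzyl ring, or a longer chain in place of benzyl, would give a step beyond the scatter at this position. A single pair also leaves open whether the ethyl ester, held constant here, has any bearing on the number.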